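A few compounds are considered here, and "the series" means these few. Any claim that something is new, unique, unknown or untested is made for them only; others in the source may bear on it.

Of the compounds shown here, three have been measured so far in a functional assay on PC-12 cells (Rattus norvegicus) for cytotoxicity, read by MTT assay, with stated times of 3 h and 2 h, tested at 5 uM; on this read-out lower numbers stand for a weaker effect and higher numbers for a stronger effect at the one concentration tested. Compound 2 `O=C(CCCCC1CCSS1)NCc1cn(CCCCCOc2ccc3ccc(=O)oc3c2)nn1` gives 64.5% and stands highest of the three numbers. Compound 3 `Cc1cc(=O)oc2cc(OCCCCCn3cc(CNC(=O)CCCCC4CCSS4)nn3)ccc12`, with a methyl in place of hydrogen on an aromatic carbon, gives 61%, and the step of a number 3.5 percentage points lower from compound 2 to compound 3 (within the scatter) lies within the scatter. Compound 1 `COc1ccc(-c2cc3ccc(OCCCn4cc(CNC(=O)CCCCC5CCSS5)nn4)cc3oc2=O)cc1` gives 52.8%, a number beyond the scatter below compound 2, but compound 1 differs from compound 2 in more than one place, so no single step between them is shown.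

Compound 4 `COc1ccc(-c2cc3ccc(OCCCCCn4cc(CNC(=O)CCCCC5CCSS5)nn4)cc3oc2=O)cc1` has not yet been measured. It differs from compound 2 by 4-methoxyphenyl in place of hydrogen on an aromatic carbon. Among the compounds with values here, no measured step covers this exact change; the one measured step of a single change was small and within the scatter. Compound 1 carries the same 4-methoxyphenyl group as compound 4 and gives a lower number than compound 2, which points toward a moderate drop. The step of a number 8.5 percentage points lower from compound 2 to compound 4 (within the scatter) is therefore expected to be a modest decrease. Compound 4 is estimated at 56%, within a range from 45% to 67%.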

Compound 4, a percentage reported as activity, at one concentration (the size of the read-out at that concentration, not a potency): 41%
Compound 4: middle estimate off by 15 percentage points, on the high side, outside the stated range (below it).
By their numbers in this assay, from the lowest: compound 4; then compounds 1, 3 and 2 (each within the scatter of the next, the first and the last beyond it).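

In this assay, 4-methoxyphenyl in place of hydrogen on this aromatic carbon gives a number 23.5 percentage points lower from compound 2 to compound 4 (beyond the scatter), whereas the earlier single change, methyl in place of hydrogen on an aromatic carbon, gave only a number 3.5 percentage points lower from compound 2 to compound 3 (within the scatter). Within the data shown here, this is therefore the first single change to move the number clearly, and at the one concentration tested the lower number stands for a weaker effect, so this position does not take a group of 8 heavy atoms without a loss in the read-out. No measured evidence accounts for the drop.

Going by these compounds, whether the loss comes from the aromatic ring itself or from its methoxy group stays open, and a plain phenyl ring at this position would separate the two. How a small group here, such as an amine, would read is also unknown.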